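The compounds below may be only part of what the source reports. "The series", "measured", "known", "first", "only" and "open" are said of these compounds alone.

Working notes on the series, values from a functional assay on HCT-116 cells (Homo sapiens) for inhibition, read by colorimetric assay, with a stated time of 3 days (on this read-out higher numbers stand for weaker inhibition and lower numbers for stronger inhibition), as follows:

- compound 1 `O=C(CCCCCCCNC(=O)c1cc(=O)c(O)co1)Nc1ccccc1` gives > 100000 nM as a limit
- compound 2 `NC(=O)C(=O)NCCCCCCCC(=O)Nc1ccccc1` gives > 100000 nM as a limit
- compound 3 `O=C(CCCCCCNC(=O)C(O)(O)C(F)(F)F)Nc1ccc(-c2ccccc2)cc1` gives 4730 nM as a number

In this assay compound 2 gives > 100000 nM and this is a limit of the assay, not a number. Compound 2 and compound 1 both stand at the limit of > 100000 nM in this assay, at which 2 of the 3 values shown sit, and so neither has a measured potency. Among the compounds with values here, compound 3 is the only compound with a number, at 4730 nM and no single-place step connects it to compound 2 or compound 4.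

Compound 4 `C/C(=N\O)C(=O)NCCCCCCC(=O)Nc1ccccc1` follows from compound 2 by a group of 7 heavy atoms (3 carbon, 2 nitrogen, 2 oxygen; no ring) in place of a group of 7 heavy atoms (3 carbon, 2 nitrogen, 2 oxygen; no ring), on a saturated chain carbon, six bonds along the chain from a carbonyl carbon and the two have the same atoms, joined differently. The group that leaves is ((carbamoylcarbonyl)amino)methyl and the group that enters has no common name.

Within the data shown here, the one measured step is a step that the two limits leave unreadable from compound 1 to compound 2 and its size gives no guide. No step beyond the scatter can be expected on this evidence in this assay and a further reading at the limit is the likeliest outcome for compound 4. The expected change is a number no higher from compound 2 to compound 4 (the limit leaves the size open) on present evidence. For compound 4 the estimated value is 100000 nM with an expected range from 30000 nM to 300000 nM on this read-out.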

Compound 4, half-maximal inhibitory concentration: > 100000 nM
Compound 4 was reported as a limit; the forecaster's own chance of this, stated with the estimate: 70%; the middle value lies on the limit itself.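

In this assay compound 4 gives > 100000 nM, which is a limit of the assay and not a number. No step can be read between compound 2 and compound 4, because both stand at the same limit: the limit of > 100000 nM in this assay, at which 3 of the 4 values shown sit.

The compounds shown leave open whether a change at this place alters potency at all; only compound 3 has a measured number, and no single-place step connects it to compound 2 or compound 4.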